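Propylsulfonyl series: stability in human liver microsomes

The compounds below may be only part of what the source reports. "The series", "measured", "known", "first", "only" and "open" are said of these compounds alone.

Measured so far:
compound 1 `CCCS(=O)(=O)N1CC=C(c2ccc3c(c2)CC(C2CCN(c4ncc(C(F)(F)F)cn4)CC2)O3)CC1` — 58%
compound 2 `CCCS(=O)(=O)N1CC=C(c2ccc3c(c2)CC(C2CCN(c4ncc(C5CC5)cn4)CC2)O3)CC1` — 58%
compound 3 `CCCc1cnc(N2CCC(C3Cc4cc(C5=CCN(S(=O)(=O)CCC)CC5)ccc4O3)CC2)nc1` — 71%

In an ADME assay (liver) for metabolic stability, with Liver microsome (Homo sapiens) as the target, using microsomes, with a stated time of 10 min (on this read-out higher numbers stand for a more stable compound and lower numbers for a less stable compound), compound 3 stands highest of the three numbers. The steps of a number 13 percentage points higher from compound 1 to compound 3 (beyond the scatter) and a number 13 percentage points higher from compound 2 to compound 3 (beyond the scatter) are both beyond the scatter, while no change at the digits printed from compound 1 to compound 2 (within the scatter) is not. All three measured steps change the group on the aromatic carbon of the pyrimidine ring.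

Compound 4 `CCCc1cnc(N2CCC(C3Cc4cc(N5CCN(S(=O)(=O)CCC)CC5)ccc4O3)CC2)nc1` differs from compound 3 at a different place: a group of 12 heavy atoms (7 carbon, 2 nitrogen, 2 oxygen, 1 sulfur; one six-membered non-aromatic ring with 2 hetero atoms) in place of a group of 12 heavy atoms (8 carbon, 1 nitrogen, 2 oxygen, 1 sulfur; one six-membered non-aromatic ring with 1 hetero atom), on an aromatic carbon. Going by the values given here, no measured step touches this position, so the measured steps only show how far this assay has moved so far. With nothing pointing either way, the expectation is a step of about a number 5 percentage points lower from compound 3 to compound 4 (within the scatter), that is no change beyond the scatter. Compound 4 is therefore estimated at 66% in this assay, with a range from 46% to 86%.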

Compound 4, percent of the compound remaining: 82%
For compound 4 the middle estimate is 16 percentage points below the measured one; the range from low to high includes it.
By their numbers in this assay, from the lowest: compounds 1 and 2 (each within the scatter of the next); then compound 3; then compound 4.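

Going by these compounds alone, with 4-(propylsulfonyl)piperazin-1-yl entering on the aromatic carbon of the fused two-ring system, this assay shows a number 11 percentage points higher from compound 3 to compound 4 (beyond the scatter), so this position also moves the read-out, not only the group changed in the earlier steps. The entering group differs in ring hetero atoms, double bonds outside aromatic rings and hydrogen-bond acceptors, and this single step does not separate these differences. Nothing available explains the step.
Open: whether a morpholine or an acetylpiperazine at this position behaves alike, and whether the step holds with trifluoromethyl or cyclopropyl in place of propyl.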